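Replacing Phenyl with 6-Amino-5-methylpyridin-3-yl in Compound 4

The compounds below may be only part of what the source reports. "The series", "measured", "known", "first", "only" and "open" are said of these compounds alone.

Of the compounds shown here, three share one core and have been measured in an in vitro assay on HEK385-7 cells for displacement of a labelled ligand from prostaglandin D2 receptor 2 (Homo sapiens); a higher number here means a weaker inhibitor, a lower number a stronger inhibitor. Compound 1 `O=C(O)Cc1sc(COc2ccc(Cl)cc2)nc1-c1ccc(Cl)cc1` gives 32 nM, compound 3 `O=C(O)Cc1sc(C(c2ccccc2)c2ccc(F)c(F)c2)nc1-c1ccc(F)cc1` gives 10 nM, and compound 2 `O=C(O)Cc1sc(C(c2ccc(F)cc2)c2ccc(F)cc2)nc1-c1ccccc1` gives 16 nM. Compound 2 has the second highest of the three numbers, yet its gap to compound 3 and its gap to compound 1 both lie within the usual scatter of this assay, so the three compounds cannot be ranked against each other on these numbers alone.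

Compound 4 `Cc1cc(-c2nc(C(c3ccc(F)cc3)c3ccc(F)cc3)sc2CC(=O)O)cnc1N` has not yet been measured. It differs from compound 2 in one place: 6-amino-5-methylpyridin-3-yl in place of phenyl on an aromatic carbon

No pair of measured compounds differs in exactly this way, so there is no shown step to lean on. The expectation for compound 4 rests on the narrow spread of the three measured values. The step from compound 2 to compound 4 is expected to be a 1.6-fold lower number from compound 2 to compound 4 (0.20 log units; within the scatter), at most a modest move toward a lower number. Compound 4 is therefore estimated at 10 nM, with a range from 3 nM to 40 nM.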

Compound 4, half-maximal inhibitory concentration: 880 nM
Compound 4: the middle estimate sits 88-fold (1.94 log units) below what was measured; the measured number lies above the stated range.
By their numbers in this assay, from the lowest: compounds 3, 2 and 1 (each within the scatter of the next, the first and the last beyond it); then compound 4.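

In this assay, this position proves far from indifferent: putting 6-amino-5-methylpyridin-3-yl in place of phenyl, on the aromatic carbon next to the ring nitrogen, gives a 55-fold higher number from compound 2 to compound 4 (1.74 log units; beyond the scatter) and so a much weaker inhibitor. Within the data shown here, none of the earlier compounds has a nitrogen in the ring at this place, so they could not show that such a swap carries so large a penalty. No measurement shown here offers an explanation for the size of this step.

The entering group differs from phenyl in three ways at once: a ring nitrogen, an amine and a methyl group, and the compounds shown leave open which of these matters. Compounds with plain pyridin-3-yl or 6-aminopyridin-3-yl at this place would begin to separate them.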